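Bromo to fluoro exchange from compound 2 to compound 3

The source may report more compounds than this note shows. Statements on the series, on what has been measured and on what is new or still open speak of the compounds shown alone.

Compound 1 `CC#CCn1c(N2CCC[C@@H](N)C2)cc(=O)n(Cc2ccc(Cl)c(C(=O)O)c2)c1=O` opens the pair of measured entries. In an assay on isolated protein for inhibition of Dipeptidyl peptidase 9 (Homo sapiens), read by fluorescence, with stated times of 15 min and 20 min (a higher number here means a weaker inhibitor, a lower number a stronger inhibitor), compound 1 reads > 100 nM, which is a limit of the assay rather than a number. Compound 2 `CC#CCn1c(N2CCC[C@@H](N)C2)cc(=O)n(Cc2ccc(Br)c(C(=O)OC)c2)c1=O` likewise reaches only a limit: in this assay compound 2 gives > 100 nM. Both known values sit at the limit of > 100 nM in this assay, at which 2 of the 2 values shown sit, so compound 2 stands with nothing resolved on the numbers shown; it cannot be ranked against compound 1.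

Compound 3 `CC#CCn1c(N2CCC[C@@H](N)C2)cc(=O)n(Cc2ccc(F)c(C(=O)OC)c2)c1=O` differs from compound 2 by fluoro in place of bromo on an aromatic carbon. Going by the values given here, no step between measured compounds is available, so the size of this change in this assay can only be guessed; with both known values at a limit, no direction beyond the scatter is expected, and a result that again ends at the limit is the likeliest outcome. Compound 3 is estimated at 200 nM, with a range from 60 nM to 1000 nM. The expected step that the limit leaves unreadable from compound 2 to compound 3 is accordingly small.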

Compound 3, half-maximal inhibitory concentration: > 100 nM
Compound 3: only a limit was reported (the forecaster's own chance of this, stated with the estimate: 70%); the middle value does not contradict the limit.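

No step can be read between compound 2 and compound 3, as both end at a limit rather than a number: the limit of > 100 nM in this assay, at which 3 of the 3 values shown sit.

The compounds shown leave open how strongly any of them inhibits in this assay, and whether fluoro in place of bromo changes that at all.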